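A few compounds are considered here, and "the series" means these few. Any claim that something is new, unique, unknown or untested is made for them only; others in the source may bear on it.

The measured compounds and their values are:

Compound 1, `CCCN(CCC)c1nc(C)nc(N(CC)c2ccc(N(C)C)cc2C)n1`: 7 nM
Compound 2, `CCN(CC)c1cc(C)nc(N(CC)c2c(Cl)cc(Br)cc2Cl)n1`: 24 nM
Compound 3, `CCCN(CCC)c1nc(C)nc(N(CC)c2ccc(N(C)C)cc2C(F)(F)F)n1`: 6 nM

In an assay on isolated protein for binding affinity to corticotropin-releasing factor receptor 1 (Homo sapiens) (on this read-out higher numbers stand for weaker inhibition and lower numbers for stronger inhibition), compound 1 stands second highest of the three numbers. Among the compounds with values here, its nearest neighbour is compound 3, reached by the only one-place step in the set, a 1.2-fold lower number from compound 1 to compound 3 (0.07 log units; within the scatter), a trifluoromethyl in place of a methyl on an aromatic carbon. The furthest is compound 2, which rests on a different core and whose value lies beyond the scatter from that of compound 1.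

Compound 4, `CCCCN(CC#N)c1nc(C)nc(N(CC)c2ccc(N(C)C)cc2C)n1`, has not yet been measured. It differs from compound 1 as follows: butyl(cyanomethyl)amino in place of dipropylamino on an aromatic carbon. Within the data shown here, the one measured step, from compound 1 to compound 3, touches the aromatic carbon of the other ring and not the amine that is exchanged here, so it bears only loosely on this change, and it was itself within the scatter. Among the measured compounds shown here, no measured pair shows a dipropylamino replaced by a butyl(cyanomethyl)amino. Compound 4 is therefore expected to give a number close to that of compound 1, the expected step being a 1.4-fold higher number from compound 1 to compound 4 (0.15 log units; within the scatter), with no direction that can be called beyond the scatter. The estimate for compound 4 is 10 nM, between 3 nM and 35 nM.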

Compound 4, inhibition constant: 8 nM
Compound 4: the middle estimate sits 1.3-fold (0.10 log units) above what was measured; the range from low to high includes it.
By their numbers in this assay, from the lowest: compounds 3, 1 and 4 (each within the scatter of the next); then compound 2.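

On the aromatic carbon between two ring nitrogen atoms, the exchange gives a 1.1-fold higher number from compound 1 to compound 4 (0.06 log units; within the scatter) in this assay, so a butyl(cyanomethyl)amino group, with its nitrile, can stand in place of dipropylamino without a change beyond the scatter. Within the data shown here, the earlier one-place step concerned the other aromatic ring, and this is the first reading of what happens when the amine itself is altered on the shared core. No measurement at hand offers an account of this outcome.

The exchange alters both arms of the amine at once, lengthening one propyl to butyl and replacing the other with cyanomethyl, and the compounds shown cannot separate the two changes, since neither a propyl(cyanomethyl)amino nor a dibutylamino group appears among them. On these data alone, it also remains open how far this position accepts other groups, such as a longer chain ending in a carboxylic acid, and whether butyl(cyanomethyl)amino would give a similar number alongside the trifluoromethyl of compound 3.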